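This account rests on a few compounds, and the source may have more. Where it says the series, first, only, none or still open, it means among the compounds named here.

Compound 1 `NC(=S)N1CCc2c(OCCCCCOc3ccc(Cl)cc3)cccc21` carries a thiourea whose amide-type nitrogen bears only hydrogen. In an ADME assay on Huh-7 cells (Homo sapiens) for cytotoxicity (a lower number here means that less compound is tolerated, a higher number that more compound is tolerated), compound 1 gives > 50000 nM, which is a limit of the measurement rather than a number. Compound 2 `N#Cc1cccc(C(=O)NC(=S)N2CCc3c(OCCCCCOc4ccc(Cl)cc4)cccc32)c1` adds a (3-cyanophenyl)carbonyl on that nitrogen, and in this assay compound 2 gives 9750 nM. Compound 3 `N#Cc1ccc(C(=O)NC(=S)N2CCc3c(OCCCCCOc4ccc(Cl)cc4)cccc32)cc1` carries a (4-cyanophenyl)carbonyl instead. In this assay compound 3 gives > 50000 nM, again a limit and not a number. So compound 3 sits at the limit of > 50000 nM in this assay, at which 2 of the 3 values shown sit, together with compound 1, while compound 2 lies clearly lower, as the step of an at least 5.1-fold higher number from compound 2 to compound 3 (0.70 log units; beyond the scatter) shows.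

Compound 4 `O=C(NC(=S)N1CCc2c(OCCCCCOc3ccc(Cl)cc3)cccc21)c1ccc(F)cc1` differs from compound 3 in one place: fluoro in place of cyano on an aromatic carbon. Within the data shown here, no measured step exchanges cyano for fluoro. The steps of an at least 5.1-fold lower number from compound 1 to compound 2 (0.70 log units; beyond the scatter) and an at least 5.1-fold higher number from compound 2 to compound 3 (0.70 log units; beyond the scatter) show that the group on this ring can move the number by at least a modest amount, whereas a step that the two limits leave unreadable from compound 1 to compound 3. Compound 4 is therefore expected to show an at least 1.6-fold lower number from compound 3 to compound 4 (0.22 log units; that floor lies within the scatter), with an estimate of 30000 nM and a range from 8000 nM to 50000 nM.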

Compound 4, half-maximal cytotoxic concentration: 31100 nM
The estimate for compound 4 lay 1.0-fold (0.02 log units) below the measured number, within the range that was stated.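

Fluoro in place of cyano gives an at least 1.6-fold lower number from compound 3 to compound 4 (0.20 log units; that floor lies within the scatter), so this position on the ring now yields a measured number in this assay rather than a limit, though that floor does not establish a real change. The (4-fluorophenyl)carbonyl group on the amide-type nitrogen likewise gives an at least 1.6-fold lower number from compound 1 to compound 4 (0.20 log units; that floor lies within the scatter), again with no established change. Only the (3-cyanophenyl)carbonyl group stands apart so far: moving from it to (4-fluorophenyl)carbonyl gives a 3.2-fold higher number from compound 2 to compound 4 (0.50 log units; beyond the scatter), which is beyond the scatter.

Going by these compounds, the true size of the cyano-to-fluoro step stays open, since one side of it is a limit of the measurement: the limit of > 50000 nM in this assay, at which 2 of the 4 values shown sit. It also remains open whether the lower number of compound 2 follows from the ring position or from the nitrile itself, a question that a (3-fluorophenyl)carbonyl group would address.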